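Two changes at one oxygen, one free acid kept

This account rests on a few compounds, and the source may have more. Where it says the series, first, only, none or still open, it means among the compounds named here.

Two measured compounds share a core and differ only at one oxygen on a saturated carbon of their chain. Compound 1 `COC(=O)c1ccc(OCCCCOc2ccc(C(=O)CC3CCCC3)c(O)c2C)cc1` carries a 4-(methoxycarbonyl)phenyl group there; in an assay on HEK293 cells for positive allosteric modulation of metabotropic glutamate receptor 2 (Rattus norvegicus), read by thallium flux, with a stated time of 2.5 min (on this read-out higher numbers stand for larger maximal responses and lower numbers for smaller maximal responses), compound 1 gives 12.2%. Compound 2 `Cc1c(OCCCCOCOc2ccc(C(=O)O)cc2)ccc(C(=O)CC2CCCC2)c1O` carries a (4-carboxyphenoxy)methyl group instead, and in this assay compound 2 gives 95.4%. The step between them is a number 83.2 percentage points higher from compound 1 to compound 2 (beyond the scatter), so compound 2 stands highest of the two numbers, with compound 1 far below it.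

Compound 3 `Cc1c(OCCCCOc2ccc(C(=O)O)cc2F)ccc(C(=O)CC2CCCC2)c1O` is the next variation. Its change from compound 2 is 4-carboxy-2-fluorophenyl in place of (4-carboxyphenoxy)methyl on an oxygen on a saturated carbon. Among the compounds with values here, the only measured step that bears on it is the one from compound 1 to compound 2, which was large; but that step altered both the group carrying the acid and the way it is joined, while compound 3 keeps a carboxylic acid, drops the extra oxygen-bearing carbon and gains a fluorine. Within the data shown here, no measured step isolates either part. Because the free acid of compound 2 gave 95.4%, compound 3 is expected to stay fairly high, with the estimated step being a number 20.4 percentage points lower from compound 2 to compound 3 (beyond the scatter). The expected value for compound 3 is 75%, within a range from 35% to 100%.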

Compound 3, largest response reached (reported as percent of maximum), in percent of the reference or control that the assay uses: 83.8%
Compound 3: middle estimate off by 8.8 percentage points, on the low side; the measured number falls inside the stated range.
By their numbers in this assay, from the lowest: compound 1; then compound 3; then compound 2.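

Compound 3 shows that a high maximal response does not depend on the (4-carboxyphenoxy)methyl group: in this assay the 4-carboxy-2-fluorophenyl group gives a number 11.6 percentage points lower from compound 2 to compound 3 (beyond the scatter), a modest loss that leaves compound 3 far above compound 1. The comparison with compound 1 is also cleaner than the earlier one, since in both compounds the aromatic ring sits directly on the oxygen, and the change still gives a number 71.6 percentage points higher from compound 1 to compound 3 (beyond the scatter), so the large rise does not require the longer link of compound 2, although the methyl ester and the fluorine both change in this step. Nothing measured here explains why the response shifts with either change.

The effects of the fluorine and of the free acid remain tangled, and so do those of the fluorine and the shorter link in the step from compound 2; a plain 4-carboxyphenyl group on the same oxygen would separate them. Also open, going by these compounds, is whether a primary amide in place of the carboxylic acid, or a chlorine in place of the fluorine, would hold the response near that of compound 3.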